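The source may report more compounds than this note shows. Statements on the series, on what has been measured and on what is new or still open speak of the compounds shown alone.

In a functional assay on KYSE-450 cells (Homo sapiens) for inhibition, read by CCK-8 assay, with a stated time of 48 h (on this read-out lower numbers stand for stronger inhibition and higher numbers for weaker inhibition), compound 1 `COc1ccc(CN(C(=O)CSC(=S)N2CCc3cc(OC)ccc32)c2cc(OC)c(OC)c(OC)c2)cc1` gives 10200 nM and compound 2 `COc1ccc(CN(C(=O)CSC(=S)N2CCCc3cc(OC)ccc32)c2cc(OC)c(OC)c(OC)c2)cc1` gives 5530 nM. Going by the values given here, compound 2 therefore stands level with compound 1, its only measured neighbour, and the two numbers cannot be told apart. Compound 3 `COc1ccc(CN(C(=O)CSC(=S)N2CCc3ccccc3C2)c2cc(OC)c(OC)c(OC)c2)cc1` has not yet been measured. It differs from compound 2 at one place, on a thiocarbonyl carbon: 1,2,3,4-tetrahydroisoquinolin-2-yl in place of 6-methoxy-1,2,3,4-tetrahydroquinolin-1-yl on a thiocarbonyl carbon. Among the compounds with values here, only one measured step bears on this change, a 1.8-fold lower number from compound 1 to compound 2 (0.27 log units; within the scatter), which replaced one group on that same carbon with another and stayed within the scatter. Within the data shown here, no measured compound carries 1,2,3,4-tetrahydroisoquinolin-2-yl, so this single step is a weak guide. No shift beyond the scatter is therefore expected in this assay, and the estimated change is a 1.3-fold higher number from compound 2 to compound 3 (0.10 log units; within the scatter). Compound 3 is expected to give 7000 nM, with an estimated range of 2500 nM to 20000 nM.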

Compound 3, half-maximal inhibitory concentration: > 20000 nM
Compound 3: no number, only a limit (the forecaster's own chance of this, stated with the estimate: 8%); middle value at least 2.8-fold (0.45 log units) away from the limit.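

Compound 3 gives no number in this assay, only a limit of the assay: the limit of > 20000 nM in this assay, at which 1 of the 3 values shown sits.

Even so, this is the first change on the thiocarbonyl carbon that can be told apart from the scatter: 1,2,3,4-tetrahydroisoquinolin-2-yl in place of 6-methoxy-1,2,3,4-tetrahydroquinolin-1-yl gives an at least 3.6-fold higher number from compound 2 to compound 3 (0.55 log units; beyond the scatter), so the group on that carbon does affect this read-out. Against 5-methoxy-2,3-dihydro-1H-indol-1-yl, the same group gives an at least 1.9-fold higher number from compound 1 to compound 3 (0.29 log units; that floor lies within the scatter), and that floor alone does not separate the two.

The change from compound 2 to compound 3 removes the methoxy and alters the ring group together, and the compounds shown cannot tell these two apart. From the compounds shown here alone, how a plain 1,2,3,4-tetrahydroquinolin-1-yl or a simple piperidine on that carbon would read remains open.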